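The source may report more compounds than this note shows. Statements on the series, on what has been measured and on what is new or still open speak of the compounds shown alone.

Measured compounds:
compound 1, `CC/C=C/C(=O)Nc1cc2c(N3CCc4ccccc43)ncnc2cc1OC`: 5890 nM
compound 2, `CC/C=C/C(=O)Nc1cc2c(N3CCc4ccccc43)ncnc2cc1O[C@@H]1CCOC1`: 9590 nM
compound 3, `CC/C=C/C(=O)Nc1cc2c(N3CCCc4ccccc43)ncnc2cc1O[C@@H]1CCOC1`: 14300 nM

In a functional assay on PC-3 cells (Homo sapiens) for antiproliferative activity, read by MTT assay, with a stated time of 72 h (on this read-out higher numbers stand for weaker inhibition and lower numbers for stronger inhibition), compound 2 gives 9590 nM. It sits between the other two: the step from compound 1 to compound 2, oxolan-3-yl in place of methyl on an oxygen on an aromatic ring, is a 1.6-fold higher number from compound 1 to compound 2 (0.21 log units; within the scatter), and the step from compound 2 to compound 3, 1,2,3,4-tetrahydroquinolin-1-yl in place of 2,3-dihydro-1H-indol-1-yl on an aromatic carbon, is a 1.5-fold higher number from compound 2 to compound 3 (0.17 log units; within the scatter). Neither of these separates the three compounds beyond the scatter.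

Compound 4, `O=C(/C=C/CN1CCCC1)Nc1cc2c(N3CCc4ccccc43)ncnc2cc1O[C@@H]1CCOC1`, differs from compound 2 at a different place: pyrrolidin-1-yl in place of methyl on a saturated chain carbon bound to a double-bonded chain carbon. Neither measured step touches the chain that carries this change, so nothing in the measured set speaks directly to its effect. Among the compounds with values here, both steps so far have been within the scatter, and no change beyond the scatter is expected here either. Compound 4 is therefore estimated at 8000 nM in this assay, within a range of 3000 nM to 25000 nM. The expected step from compound 2 to compound 4 is a 1.2-fold lower number from compound 2 to compound 4 (0.08 log units; within the scatter).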

Compound 4, half-maximal inhibitory concentration: 1510 nM
The estimate for compound 4 lay 5.3-fold (0.72 log units) above the measured number; the whole stated range lies above it.
By their numbers in this assay, from the lowest: compound 4; then compounds 1, 2 and 3 (each within the scatter of the next, the first and the last beyond it).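

In this assay, the change of pyrrolidin-1-yl in place of methyl on a saturated chain carbon bound to a double-bonded chain carbon gives a 6.4-fold lower number from compound 2 to compound 4 (0.80 log units; beyond the scatter). Within the data shown here, of the three places changed in this set, this chain is the only one where a single change moves the number beyond the scatter, since the steps at the other two stay within it. The change adds one five-membered ring with one nitrogen, but nothing available explains the lower number.

Going by these compounds, this rests on a single pair, so it remains open whether the ring itself matters or whether an open-chain dimethylamino group, piperidin-1-yl or morpholin-4-yl would do the same. On these data alone, it is also open whether the step would hold with 1,2,3,4-tetrahydroquinolin-1-yl on the core.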